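The compounds below may be only part of what the source reports. "The series", "measured", "known", "first", "only" and "open" are said of these compounds alone.

Measured so far in an ADME assay on microsomes from liver (Rattus norvegicus) for metabolic stability, read by LC-MS, using NADPH, at 37 degrees C; a lower number here means that the compound disappears faster, a higher number that the compound lasts longer:

compound 1, `Cc1oc(-c2ccc(Cl)cc2)nc1CN1CCC(C(=O)NCCCN2C[C@H](C)C[C@H](C)C2)CC1`: > 0.5 h
compound 2, `Cc1ccccc1-c1nc(CN2CCC(C(=O)NCCCN3CCC(C)CC3)CC2)c(C)o1`: > 0.5 h
compound 3, `Cc1ccccc1-c1nc(CN2CCC(C(=O)N3CCN(CCN(C)C)CC3)CC2)c(C)o1`: > 0.5 h

In this assay compound 1 gives > 0.5 h, which is a limit of the assay and not a number. Compound 2 likewise gives > 0.5 h, a limit. Compound 3 gives > 0.5 h, again a limit. Among the measured compounds shown here, the only pair that differs in one place is the step that the two limits leave unreadable from compound 2 to compound 3, whose size cannot be read since both ends are limits. This is summed up by the limit of > 0.5 h in this assay, at which 3 of the 3 values shown sit, so the measured values give no direction of change anywhere in the set.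

Compound 4 is `Cc1ccc(-c2nc(CN3CCC(C(=O)NCCCN4C[C@H](C)C[C@H](C)C4)CC3)c(C)o2)c(C)c1`. It differs from compound 1 by 2,4-dimethylphenyl in place of 4-chlorophenyl on an aromatic carbon. For the measured compounds named here, no measured step touches this position, and the one measured step, on the carbonyl carbon, is unreadable, so there is no evidence for a change beyond the scatter in either direction. Given that compound 1 gives > 0.5 h, compound 4 is expected to reach the same limit, with an estimate of 0.7 h and a range from 0.4 h to 1.5 h. The expected step that the limit leaves unreadable from compound 1 to compound 4 is therefore estimated to lie within the scatter.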

Compound 4, half-life: > 0.5 h
Compound 4: only a limit was reported; the forecaster's own chance of this, stated with the estimate: 70%; the middle value lies beyond the limit too.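

Compound 4 gives > 0.5 h in this assay as a limit of the assay and not a number. Among the compounds shown here, compound 1 also sits at a limit, so no step between compound 1 and compound 4 can be read: the limit of > 0.5 h in this assay, at which 4 of the 4 values shown sit. The compounds shown leave open how long any of them lasts beyond that limit, and whether either change affects the half-life at all.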